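This account rests on a few compounds, and the source may have more. Where it says the series, first, only, none or still open, it means among the compounds named here.

The shared core of compound 1 `CC(C(=O)NCc1ccc(C(F)(F)F)nc1NCc1ccccc1)c1ccc(NS(C)(=O)=O)c(F)c1` carries a benzylamino group, and in a functional assay on CHO-K1 cells for antagonist activity at transient receptor potential cation channel subfamily V member 1 (Homo sapiens), read by FLIPR (on this read-out lower numbers stand for stronger inhibition and higher numbers for weaker inhibition), compound 1 gives 15.8 nM. Compound 2 `CC(C(=O)NCc1ccc(C(F)(F)F)nc1N1CCCC1)c1ccc(NS(C)(=O)=O)c(F)c1` gives 0.6 nM in this assay, while compound 3 `COC1CCN(c2nc(C(F)(F)F)ccc2CNC(=O)C(C)c2ccc(NS(C)(=O)=O)c(F)c2)CC1` gives 2.4 nM, the second highest of the three numbers; the three steps are a 26-fold lower number from compound 1 to compound 2 (1.42 log units; beyond the scatter), a 6.6-fold lower number from compound 1 to compound 3 (0.82 log units; beyond the scatter) and a 4.0-fold higher number from compound 2 to compound 3 (0.60 log units; beyond the scatter). Compound 4 `CCCCOC1CCN(c2nc(C(F)(F)F)ccc2CNC(=O)C(C)c2ccc(NS(C)(=O)=O)c(F)c2)CC1` differs from compound 3 by propyl in place of hydrogen on a saturated chain carbon bound to an oxygen on a saturated carbon. Within the data shown here, no measured step touches this chain, since every step so far exchanged the group on the aromatic carbon, so only a small step from compound 3 to compound 4 is expected, likely within the scatter: a 1.5-fold higher number from compound 3 to compound 4 (0.16 log units; within the scatter). Compound 4 is therefore estimated at 3.5 nM, in a range from 1.2 nM to 10 nM.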

Compound 4, inhibition constant: 3.5 nM
Compound 4: the middle estimate sits on the measured number at the digits printed; the range from low to high includes it.
By their numbers in this assay, from the lowest: compound 2; then compounds 3 and 4 (each within the scatter of the next); then compound 1.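

Exchanging methoxy for butoxy gives a 1.5-fold higher number from compound 3 to compound 4 (0.16 log units; within the scatter) in this assay, the first read on this chain, so propyl in place of hydrogen at this position causes no shift beyond the scatter. The gaps to the other groups on the aromatic carbon remain modest, with a 5.8-fold higher number from compound 2 to compound 4 (0.77 log units; beyond the scatter) and a 4.5-fold lower number from compound 1 to compound 4 (0.65 log units; beyond the scatter). Nothing available explains why this chain is accepted. Open, as far as these compounds go, is whether a longer chain, a terminal amine or a carboxylic acid on this oxygen-bound carbon would also stay within the scatter of compound 3.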